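Swapping the spiro amine for an isopropylpiperazine sulfonamide

A few compounds are considered here, and "the series" means these few. Any claim that something is new, unique, unknown or untested is made for them only; others in the source may bear on it.

Compound 1 `CN1CCC2(CC1)CC(S(=O)(=O)c1c(Cl)ccc(NC(=O)Nc3cccc(F)c3Cl)c1O)C2` gives the highest exposure of the three compounds measured in an ADME assay on the whole organism (blood, Mus musculus, strain C57BL/6) for pharmacokinetics, read by HPLC, with a stated time of 4 h, at a dose of 2 mg/kg by the intraperitoneal route (on this read-out higher numbers stand for higher exposure at the dose given and lower numbers for lower exposure), at 1390 ng.h/mL. Compound 2 `CN1CCN(S(=O)(=O)c2c(Cl)ccc(NC(=O)Nc3cccc(Cl)c3Cl)c2O)CC1` gives 303 ng.h/mL, and compound 3 `CCS(=O)(=O)c1c(Cl)ccc(NC(=O)Nc2cccc(Cl)c2Cl)c1O` gives 256 ng.h/mL. Compound 4 `CC(C)N1CCN(S(=O)(=O)c2c(Cl)ccc(NC(=O)Nc3cccc(F)c3Cl)c2O)CC1` differs from compound 1 by a group of 9 heavy atoms (7 carbon, 2 nitrogen; one six-membered non-aromatic ring with 2 hetero atoms) in place of a group of 10 heavy atoms (9 carbon, 1 nitrogen; one four-membered non-aromatic ring of carbon only, one six-membered non-aromatic ring with 1 hetero atom), on a sulfonyl sulfur. Going by the values given here, only one measured step touches the sulfonyl sulfur: a 1.2-fold lower number from compound 2 to compound 3 (0.07 log units; within the scatter), so a change at that position has so far left the exposure essentially unchanged. Still, the lower values of compound 2 and compound 3, which also carry a different urea aryl group, leave the outcome uncertain. Compound 4 is therefore expected to show a 2.3-fold lower number from compound 1 to compound 4 (0.36 log units; beyond the scatter), with an estimated exposure of 600 ng.h/mL and a likely range from 200 ng.h/mL to 1600 ng.h/mL.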

Compound 4, area under the concentration-time curve: 52.9 ng.h/mL
For compound 4 the middle estimate is 11-fold (1.05 log units) above the measured one; the measured number lies below the stated range.
By their numbers in this assay, from the lowest: compound 4; then compounds 3 and 2 (each within the scatter of the next); then compound 1.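

In this assay, the group on the sulfonyl sulfur turns out to matter greatly: the result is a 26-fold lower number from compound 1 to compound 4 (1.42 log units; beyond the scatter), whereas the earlier step at this place, a 1.2-fold lower number from compound 2 to compound 3 (0.07 log units; within the scatter), stayed within the scatter. The rest of the structure is shared. This large drop goes with this one change of group. No measurement shown here explains the drop.

Still open, on these data alone, is whether the piperazine ring or its isopropyl carries the loss, and what exposure a morpholine ring on the sulfonyl sulfur would give.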